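This account rests on a few compounds, and the source may have more. Where it says the series, first, only, none or still open, it means among the compounds named here.

Three compounds from this series were tested in a functional assay on ECa-109 cells (Homo sapiens) for inhibition, read by MTT assay, with a stated time of 72 h (on this read-out higher numbers stand for weaker inhibition and lower numbers for stronger inhibition), and none of them gave a number. Compound 1, `Fc1ccccc1Cn1cc(CSC(=S)N2CCNCC2)nn1`, reached only the limit of the assay, reported as > 128000 nM. Compound 2, `CC(C)(C)OC(=O)N1CCN(C(=S)SCc2cn(-c3ccccc3F)nn2)CC1`, likewise reached only the limit, reported as > 128000 nM. Compound 3, `Cc1cc(=O)oc2cc(OCCn3cc(CSC(=S)N4CCN(C(=O)OC(C)(C)C)CC4)nn3)ccc12`, also stopped at the limit, reported as > 128000 nM. Compound 2 therefore stands nowhere in particular on these numbers: its result is a limit and not a value, and the two other results shown are limits as well. Going by the values given here, the three measurements share (the limit of > 128000 nM in this assay, at which 3 of the 3 values shown sit), so no step between measured compounds can be computed, and nothing in the data distinguishes one compound from another.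

Compound 4, `Cc1ccc(-n2cc(CSC(=S)N3CCN(C(=O)OC(C)(C)C)CC3)nn2)cc1`, has not yet been measured in this assay. It differs from compound 2 in one place: 4-methylphenyl in place of 2-fluorophenyl on an aromatic nitrogen. Since compound 2 gave only a limit, and every other compound shown did the same, no direction can be read from the data for this change. The step from compound 2 to compound 4 is expected to be none beyond the scatter, a step that the limit leaves unreadable from compound 2 to compound 4, and the most likely outcome is again a limit. Compound 4 is accordingly estimated at 160000 nM in this assay, within a range from 50000 nM to 500000 nM.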

Compound 4, half-maximal inhibitory concentration: 114000 nM
Beside the measured number, compound 4's estimate is 1.4-fold (0.15 log units) above it; the measured number falls inside the stated range.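

In this assay compound 4 returns a measured number, 114000 nM, the only result shown that is not a limit, so this position on the aromatic nitrogen is the first place in the series where a change is seen to yield a readable value. Placing 4-methylphenyl in place of 2-fluorophenyl gives an at least 1.1-fold lower number from compound 2 to compound 4 (0.05 log units; that floor lies within the scatter), and since that floor lies within the usual scatter, the change cannot be said to have strengthened inhibition, however clean the move from a limit to a number may look. The true size of the step remains unknown because compound 2 is fixed only by a limit, as are the other compounds shown: the limit of > 128000 nM in this assay, at which 3 of the 4 values shown sit.

The compounds shown do not separate the loss of the fluorine from the gain of the methyl, a question that plain phenyl, 2-methylphenyl or 4-fluorophenyl on the same nitrogen would address. They also leave open whether a group such as 4-methoxyphenyl or a benzyl carrying a methyl would bring the values further from the limit of the assay.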